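Hydrogen for methyl on an aromatic oxygen in compound 3

The source may report more compounds than this note shows. Statements on the series, on what has been measured and on what is new or still open speak of the compounds shown alone.

Three members of the series have numbers in an assay for inhibition of solute carrier family 22 member 12 (Homo sapiens), read by scintillation counting, with a stated time of 60 min, tested at 50 uM; on this read-out lower numbers stand for less inhibition and higher numbers for more inhibition at the one concentration tested (going by the name of the read-out). Compound 1 `CCc1cc2cc(OC)cc(C(=O)c3ccc(OC)cc3)c2o1` gives 5.2% in this assay. Compound 2 `CCc1cc2cc(O)cc(C(=O)c3ccc(O)cc3)c2o1` gives 41% in this assay. Compound 3 `CCc1cc2c(C(=O)c3ccc(O)cc3)cc(OC)cc2o1` gives 62.4% in this assay, the highest of the three numbers; compound 2 is the nearest to it and compound 1 the furthest, both gaps beyond the scatter. Among the compounds with values here, no two of these measured compounds differ in one place only, so no single-change step is available within the measured set, and what the three numbers show is only that the two compounds carrying a hydroxy group on the benzoyl ring sit above compound 1.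

Compound 4 `CCc1cc2c(C(=O)c3ccc(O)cc3)cc(O)cc2o1` is the next member, not yet measured in this assay. It differs from compound 3 in one place: hydrogen in place of methyl on an oxygen on an aromatic ring. Within the data shown here, since no measured pair shows this change on its own, the size of the step from compound 3 to compound 4 has to be guessed from the series as a whole. A small increase, or no change beyond the scatter, is the expectation, given that compound 2 with two hydroxy groups gives 41% and compound 3 gives 62.4%. The expected step of a number 3.6 percentage points higher from compound 3 to compound 4 (within the scatter) is therefore modest. Compound 4 is estimated at 66% in this assay, within a range from 46% to 86%.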

Compound 4, a percentage reported as inhibition, at one concentration (the size of the read-out at that concentration, not a potency): 41%
Compound 4: middle estimate off by 25 percentage points, on the high side, outside the stated range (below it).
By their numbers in this assay, from the lowest: compound 1; then compounds 2 and 4 (each within the scatter of the next); then compound 3.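

In this assay, within the data shown here, methoxy to hydroxy on an oxygen on an aromatic ring gives the only single-change step so far, a number 21.4 percentage points lower from compound 3 to compound 4 (beyond the scatter), and this step lies beyond the scatter. Among these compounds, with everything else in the structure held constant, the methyl on this oxygen therefore goes with more inhibition at the one concentration tested, a link that the earlier compounds could not show, as none of them differed from another in one place only. No measurement is available that accounts for the size or direction of this step, and a single pair gives its reading at this place alone.

Going by these compounds, it remains open whether a longer ether such as ethoxy at this oxygen would carry the number further up or back down, and whether an amine or a carboxylic acid in the same place would compare with methoxy or with hydroxy. On these data alone, it is also open whether the same change on the other hydroxy-bearing oxygen, or a longer chain in place of the ethyl group, would give a step of similar size.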